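A few compounds are considered here, and "the series" means these few. Any claim that something is new, unique, unknown or untested is made for them only; others in the source may bear on it.

Three compounds of a shared core have been examined in a functional assay on the whole organism with Rattus norvegicus as the target, at a dose of 20 mg/kg by the oral route; on this read-out higher numbers stand for more inhibition at the one dose given (going by the name of the read-out) and lower numbers for less inhibition. Compound 1, `NC(=O)/C=C1\CCc2c(Cl)cccc21`, gives 58% in this assay. Compound 2, `CC(C)NC(=O)/C=C1\CCc2ccc(F)cc21`, gives 71% in this assay. Compound 3, `NC(=O)/C=C1\CCc2ccc(Br)cc21`, gives 21% in this assay. On these three numbers compound 2 stands highest: the nearest of the others is compound 1, whose number lies lower by a gap beyond the scatter, and the furthest is compound 3, whose number lies far lower, also beyond the scatter. Within the data shown here, no two of the three compounds differ in a single place, so no measured step isolates any one change.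

Compound 4, `CCN(C)C(=O)/C=C1\CCc2ccc(F)cc21`, has not yet been measured in this assay. It differs from compound 2 by ethyl(methyl)amino in place of isopropylamino on a carbonyl carbon. The two compounds hold the same atoms, joined differently. Among the measured compounds shown here, no measured pair shows this change or any change at the carbonyl carbon, so nothing in the data gives the size or direction of its effect. A step of moderate size downward from compound 2 to compound 4 is expected, of about a number 16 percentage points lower from compound 2 to compound 4 (beyond the scatter), though a result within the scatter would not be surprising. For compound 4 a value of 55% in this assay is estimated, within a range from 25% to 80%.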

Compound 4, a percentage reported as inhibition, in the whole organism at one dose (the size of the read-out at that dose, not a potency): 44%
Compound 4: the middle estimate sits 11 percentage points above what was measured, within the range that was stated.
By their numbers in this assay, from the lowest: compound 3; then compound 4; then compound 1; then compound 2.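

In this assay, among these compounds, the swap of isopropylamino for ethyl(methyl)amino on a carbonyl carbon gives the first step that can be read at this position, a number 27 percentage points lower from compound 2 to compound 4 (beyond the scatter). The two groups hold the same atoms, so this position does not respond only to which atoms are present: how they are joined also counts, and with that rearrangement the amide hydrogen of isopropylamino is lost. Nothing measured here tells whether the loss of that hydrogen or the different arrangement of the carbon chains carries the step.

The compounds shown leave open how a single group on the amide nitrogen compares with two, since a pair such as cyclopropylamino and n-propylamino, or dimethylamino and a pyrrolidine amide, would separate the shape of the chains from the presence of the amide hydrogen. Also open, on these data alone, is whether the step holds with the chlorine or bromine of compound 1 and compound 3, as both carry an unsubstituted amide and differ from compound 2 in more than one place.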